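Triazolyl adenosine analogues: benzyl to butyl on the triazole

A few compounds are considered here, and "the series" means these few. Any claim that something is new, unique, unknown or untested is made for them only; others in the source may bear on it.

Measured compounds:
compound 1 `CNc1nc(-n2cc(-c3ccccc3)nn2)nc2c1ncn2[C@@H]1O[C@H](CO)[C@@H](O)[C@H]1O` — 14.9 nM
compound 2 `CCNC(=O)[C@H]1O[C@@H](n2cnc3c(NC)nc(-n4cc(Cc5ccccc5)nn4)nc32)[C@H](O)[C@@H]1O` — 2.8 nM
compound 3 `CNc1nc(-c2cn(Cc3cccc(Cl)c3)nn2)nc2c1ncn2[C@@H]1O[C@H](CO)[C@@H](O)[C@H]1O` — 81.1 nM

In an assay on CHO cells for displacement of a labelled ligand from adenosine receptor A3 (Homo sapiens) (on this read-out lower numbers stand for stronger inhibition and higher numbers for weaker inhibition), compound 2 gives 2.8 nM, the lowest of the three numbers shown. Compound 1 gives 14.9 nM, a higher number beyond the scatter, and compound 3 gives 81.1 nM, higher still. Among the measured compounds shown here, compound 2 combines the ethylamide on the sugar with a benzyl group on the triazole; no pair among the measured compounds differs in one place, so the weight of either feature on its own is not known from these data.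

Compound 4 `CCCCc1cn(-c2nc(NC)c3ncn([C@@H]4O[C@H](C(=O)NCC)[C@@H](O)[C@H]4O)c3n2)nn1` has not yet been measured. It differs from compound 2 in one place:

propyl in place of phenyl on a saturated chain carbon bound to an aromatic carbon

For the measured compounds named here, no measured pair shows the effect of this change, so expectation rests on compound 2 alone. The step from compound 2 to compound 4 is expected to be modest, toward a higher number, and may not clear the scatter: a 2.1-fold higher number from compound 2 to compound 4 (0.33 log units; beyond the scatter). Compound 4 is therefore estimated at 6 nM, with a range from 1.5 nM to 25 nM.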

Compound 4, inhibition constant: 5.6 nM
Estimate against measurement, compound 4: 1.1-fold (0.03 log units) above; the range from low to high includes it.
By their numbers in this assay, from the lowest: compounds 2 and 4 (each within the scatter of the next); then compound 1; then compound 3.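

In this assay, the first pair differing in one place reads a 2.0-fold higher number from compound 2 to compound 4 (0.30 log units; within the scatter) and so gives a direct view of benzyl to butyl. On a saturated chain carbon bound to an aromatic carbon, with the ethylamide sugar held constant, the six-membered aromatic ring can give way to propyl, a group with no ring, without a step that clears the scatter, so this position accepts both groups on this read-out. No measurement on hand accounts for the two groups reading alike.

Open, on these data alone, is whether a longer chain such as hexyl, or a propyl chain ending in an amine or a carboxylic acid, also stays within the scatter of compound 2. Open too, as far as these compounds go, is whether butyl reads the same on the hydroxymethyl sugar of compound 1 and compound 3.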